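A few compounds are considered here, and "the series" means these few. Any claim that something is new, unique, unknown or untested is made for them only; others in the source may bear on it.

Working notes, a functional assay on the whole organism (strain Sprague-Dawley) for inhibition, with Rattus norvegicus as the target; a lower number here means that less compound is needed, a higher number that more compound is needed for the effect.

Compound 1 `O=c1c(-c2nn[nH]n2)c[nH]c2ccccc12` gives > 20 mg/kg, a limit of the assay.
Compound 2 `O=c1c(-c2nn[nH]n2)c[nH]c2c(C(F)(F)F)cccc12` gives > 25 mg/kg, likewise a limit.

Compound 2 thus stands only at a limit, and the other value shown is a limit too: the limit of > 20 mg/kg in this assay, at which 1 of the 2 values shown sits, and (the limit of > 25 mg/kg in this assay, at which 1 of the 2 values shown sits). Going by the values given here, the single measured step, a step that the two limits leave unreadable from compound 1 to compound 2, is therefore not readable in size.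

Compound 3 `CC(C)c1cccc2c(=O)c(-c3nn[nH]n3)c[nH]c12` differs from compound 2 by isopropyl in place of trifluoromethyl on an aromatic carbon. Among the compounds with values here, no measured step bears on this change, so no shift beyond the scatter is expected. Compound 3 is estimated at 30 mg/kg, range 15 mg/kg to 60 mg/kg, an expected step that the limit leaves unreadable from compound 2 to compound 3 in this assay.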

Compound 3, minimum effective dose: 10 mg/kg
Beside the measured number, compound 3's estimate is 3.0-fold (0.48 log units) above it; measured number outside the range, below it.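

In this assay, going by these compounds alone, isopropyl in place of trifluoromethyl on this aromatic carbon gives an at least 2.5-fold lower number from compound 2 to compound 3 (0.39 log units; beyond the scatter), the first readable change at this position. With hydrogen as the reference, isopropyl gives an at least 2.0-fold lower number from compound 1 to compound 3 (0.30 log units; that floor lies within the scatter), so a gain over the core of compound 1 is not established. The step from trifluoromethyl is only a floor because compound 2 stands at a limit: the limit of > 25 mg/kg in this assay, at which 1 of the 3 values shown sits.

Still open, going by these compounds, is how far the true numbers of compound 1 and compound 2 lie from their limits. Also open, on these data alone, is whether a longer chain, a tert-butyl group or an amine on this carbon would match isopropyl.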